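Cyclopentyl Ether in Place of an Alkyne Chain

The source may report more compounds than this note shows. Statements on the series, on what has been measured and on what is new or still open speak of the compounds shown alone.

Compound 1 `Nc1ccc2cccc(OCCC3CCCCC3)c2n1`: 808 nM
Compound 2 `CC#CCCOc1cccc2ccc(N)nc12`: > 2000 nM

In an assay on cells with melanin-concentrating hormone receptor 1 (Homo sapiens) as the target, read by radioligand binding (a higher number here means a weaker inhibitor, a lower number a stronger inhibitor), compound 1 gives 808 nM. Compound 2 reaches only the limit of this assay, > 2000 nM (the limit of > 2000 nM in this assay, at which 1 of the 2 values shown sits). Within the data shown here, the single measured step, an at least 2.4-fold higher number from compound 1 to compound 2 (0.39 log units; beyond the scatter), shows the saturated ring doing better than the alkyne chain. Compound 3 `Nc1ccc2cccc(OC3CCCC3)c2n1` carries cyclopentyl in place of pent-3-yn-1-yl on an oxygen on an aromatic ring. A saturated ring returns here, so compound 3 is expected to recover part of that loss, an at least 1.3-fold lower number from compound 2 to compound 3 (0.12 log units; that floor lies within the scatter), although the limit on compound 2 leaves the size of the gain uncertain. Compound 3 is therefore estimated at 1500 nM, between 500 nM and 4500 nM.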

Compound 3, half-maximal inhibitory concentration: > 2000 nM
Compound 3 gave a limit, no number; the forecaster's own chance of this, stated with the estimate: 35%; middle value at least 1.3-fold (0.12 log units) from the limit.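

Compound 2 and compound 3 both stop at a limit rather than a number, so the step between them cannot be read: the limit of > 2000 nM in this assay, at which 2 of the 3 values shown sit.

On these data alone, how cyclopentyl and pent-3-yn-1-yl truly compare in this assay stays open.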